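A few compounds are considered here, and "the series" means these few. Any claim that something is new, unique, unknown or untested is made for them only; others in the source may bear on it.

Of the compounds shown here, two have been measured in a functional assay on HEK293 cells for activation of melanin-concentrating hormone receptor 1 (Homo sapiens), read by inositol phosphate accumulation (on this read-out higher numbers stand for an effect only at larger amounts of compound and lower numbers for an effect already at smaller amounts), so far. Compound 1 `CC(C)c1cc(N)c2cc(NC(=O)/C=C/c3ccc(C(F)(F)F)cc3)ccc2n1` gives 160 nM. Compound 2 `CCC(C)c1cc(N)c2cc(NC(=O)/C=C/c3ccc(C(F)(F)F)cc3)ccc2n1` gives 44 nM. Among the measured compounds shown here, the single step between them, a 3.6-fold lower number from compound 1 to compound 2 (0.56 log units; beyond the scatter), is a methyl in place of hydrogen on a saturated chain carbon, two bonds along the chain from an aromatic carbon. For the measured compounds named here, compound 2 thus stands at the lowest of the two numbers, with compound 1 its only neighbour, separated by that step.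

Compound 3 `Nc1cc(-c2ccccc2)nc2ccc(NC(=O)/C=C/c3ccc(C(F)(F)F)cc3)cc12` is not yet measured. It differs from compound 2 by phenyl in place of sec-butyl on an aromatic carbon. Going by the values given here, the one measured step went towards a lower number when the group at this place grew by a methyl; the change to phenyl enlarges the group at the same place again, but no measured step exchanges a saturated chain for an aromatic ring, so the analogy is loose. Compound 3 is therefore expected to give a number near that of compound 2, with a 1.5-fold lower number from compound 2 to compound 3 (0.17 log units; within the scatter) as the estimated step in this assay. Compound 3 is estimated at 30 nM, with a range from 8 nM to 120 nM.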

Compound 3, half-maximal effective concentration: 6600 nM
The estimate for compound 3 lay 220-fold (2.34 log units) below the measured number; measured number above the stated range.
By their numbers in this assay, from the lowest: compound 2; then compound 1; then compound 3.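

In this assay, the place next to the ring nitrogen proves highly sensitive to the kind of group it carries: the change from sec-butyl to phenyl gives a 150-fold higher number from compound 2 to compound 3 (2.18 log units; beyond the scatter) and the change from isopropyl to phenyl gives a 41-fold higher number from compound 1 to compound 3 (1.62 log units; beyond the scatter) in the same direction. Among the compounds shown here, both of these steps are large, whereas the only step between saturated chains, a 3.6-fold lower number from compound 1 to compound 2 (0.56 log units; beyond the scatter), is modest, so the earlier pair gave no sign of how much the number could move at this place. Group size alone does not order the three compounds, as the step from isopropyl to sec-butyl lowers the number while compound 3, with the largest group by heavy atoms, goes against that trend; no evidence on the origin of this difference is available.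

Going by these compounds, it remains open whether the higher number belongs to the aromatic ring as such or to the loss of a saturated chain, which a cyclohexyl group or a benzyl group at the same place could separate. On these data alone, it is also open how far the trend among saturated chains extends, for instance to a longer chain such as pentyl.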